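The source may report more compounds than this note shows. Statements on the series, on what has been measured and on what is new or still open speak of the compounds shown alone.

In an ADME assay on microsomes from liver (Homo sapiens) for metabolic stability (on this read-out higher numbers stand for a longer-lived compound and lower numbers for a shorter-lived compound), compound 1 `COc1cc(OCc2csc(-c3ccc(C(F)(F)F)cc3)n2)c2cc(-c3cn4nc(OC)sc4n3)oc2c1` gives > 2 h, which is a limit of the assay and not a number. Within the data shown here, compound 2 `COc1cc(OCc2cccc(-c3ccc(OC)nc3)c2)c2cc(-c3cn4nc(OC)sc4n3)oc2c1` gives 0.733 h, the only exact number so far, which makes it the natural starting point for judging a close relative.

That relative is compound 3 `COc1cc(OCc2cccc(-c3cnc(OC)nc3)c2)c2cc(-c3cn4nc(OC)sc4n3)oc2c1`. Among the measured compounds shown here, its one structural change is 2-methoxypyrimidin-5-yl in place of 6-methoxypyridin-3-yl on an aromatic carbon. The rest of the molecule stays the same, and the two groups being exchanged are of equal size by heavy-atom count.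

For the measured compounds named here, no measured pair of compounds shows what an exchange of this kind does. The expected change in this assay is therefore small, a 1.4-fold higher number from compound 2 to compound 3 (0.13 log units; within the scatter), leaning slightly towards a longer half-life and possibly staying within the usual scatter. For compound 3, the half-life is estimated at 1 h, with an expected range from 0.5 h to 2 h.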

Compound 3, half-life: 0.6 h
The estimate for compound 3 lay 1.7-fold (0.22 log units) above the measured number, and the stated range covers the measured number.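

In this assay, putting 2-methoxypyrimidin-5-yl in place of 6-methoxypyridin-3-yl gives a 1.2-fold lower number from compound 2 to compound 3 (0.09 log units; within the scatter), so the two compounds cannot be told apart on half-life. Among these compounds, this is the only measured pair for this exchange, which sits on an aromatic carbon of a six-membered aromatic ring of carbon only, meta to a large group, and here a ring with 2 hetero atoms and a ring with 1 hetero atom give values within the scatter of each other. Nothing measured here offers a reason for this result.

The compounds shown leave open what happens at this position with a group of a different kind, such as an amine or a carboxylic acid in place of the methoxy-bearing ring. One pair also cannot show whether the same exchange would give a similar result on a different core.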